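Dimethoxyphenyl in Place of Phenyl on a Coumarin Chalcone

The compounds below may be only part of what the source reports. "The series", "measured", "known", "first", "only" and "open" are said of these compounds alone.

Compound 2 `COc1cccc(COc2ccc3cc(C(=O)/C=C/c4ccccc4)c(=O)oc3c2)c1` gives only a limit in a functional assay on K562 cells (Homo sapiens) for cytotoxicity, read by MTT assay, with a stated time of 72 h (on this read-out lower numbers stand for stronger inhibition and higher numbers for weaker inhibition), namely > 100000 nM. Compound 1 `COc1cccc(COc2ccc3cc(C(=O)/C=C/c4ccc(C)cc4)c(=O)oc3c2)c1` likewise gives only a limit in this assay, > 50000 nM. The step that the two limits leave unreadable from compound 1 to compound 2 cannot be read since both values sit at limits the limit of > 100000 nM in this assay, at which 1 of the 2 values shown sits (the limit of > 50000 nM in this assay, at which 1 of the 2 values shown sits). Compound 3 `COc1cccc(COc2ccc3cc(C(=O)/C=C/c4cccc(OC)c4OC)c(=O)oc3c2)c1` carries 2,3-dimethoxyphenyl in place of phenyl on a double-bonded chain carbon bound to a double-bonded chain carbon. Going by the values given here, no measured step reads this change, and no compound of the shared core has yet given a number rather than a limit. Compound 3 is therefore expected at 80000 nM, within a range from 20000 nM to 200000 nM. The expected step of an at least 1.2-fold lower number from compound 2 to compound 3 (0.09 log units; that floor lies within the scatter) is thus estimated as no change beyond the scatter.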

Compound 3, half-maximal inhibitory concentration: 45500 nM
Estimate against measurement, compound 3: 1.8-fold (0.25 log units) above; measured number inside the range.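

Going by these compounds alone, compound 3 is the first compound of the shared core to give a number rather than a limit in this assay, and 2,3-dimethoxyphenyl in place of phenyl gives an at least 2.1-fold lower number from compound 2 to compound 3 (0.34 log units; beyond the scatter). In place of 4-methylphenyl, the same group gives an at least 1.0-fold lower number from compound 1 to compound 3 (0.04 log units; that floor lies within the scatter), so only the change from phenyl is shown beyond the scatter. The change from phenyl can be read only as a floor, because compound 2 stands at a limit: the limit of > 100000 nM in this assay, at which 1 of the 3 values shown sits.

The compounds shown leave open whether both methoxy groups are needed for this lower number. They also leave open how an amine or a carboxylic acid on the ring at this place would read.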